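Working notes: methyl on the anilino ring of compound 1

The source may report more compounds than this note shows. Statements on the series, on what has been measured and on what is new or still open speak of the compounds shown alone.

Measured in a functional assay on DU-145 cells (Homo sapiens) for inhibition, read by CCK-8 assay, with a stated time of 72 h; on this read-out lower numbers stand for stronger inhibition and higher numbers for weaker inhibition:
- compound 1 `O=C(/C=C/c1cccnc1)NCCCCCCc1cccc(S(=O)(=O)Nc2ccccc2)c1`: 6.73 nM
- compound 2 `O=C(/C=C/c1cccnc1)NCCCCCCCc1cccc(S(=O)(=O)Nc2ccccc2)c1`: 429 nM

Compound 1 holds the lower of the two numbers in this assay, and its gap to compound 2 lies beyond the scatter. Next in line is compound 3 `Cc1ccc(NS(=O)(=O)c2cccc(CCCCCCNC(=O)/C=C/c3cccnc3)c2)cc1`, which carries methyl in place of hydrogen on an aromatic carbon, para to a large group, turning phenyl into 4-methylphenyl: methyl in place of hydrogen on an aromatic carbon. Within the data shown here, no measured pair shows a change of this kind, so the expectation starts from compound 1 at 6.73 nM alone. A small rise is expected, about the size of the scatter, and the estimated 1.8-fold higher number from compound 1 to compound 3 (0.25 log units; within the scatter) reflects that. The range stays wide, since the two measured values lie far apart. Compound 3 is expected at 12 nM, with an estimated range of 3 nM to 50 nM.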

Compound 3, half-maximal inhibitory concentration: 34.4 nM
Compound 3: the middle estimate sits 2.9-fold (0.46 log units) below what was measured, and the stated range covers the measured number.
By their numbers in this assay, from the lowest: compound 1; then compound 3; then compound 2.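

In this assay, methyl in place of hydrogen on the anilino ring gives a 5.1-fold higher number from compound 1 to compound 3 (0.71 log units; beyond the scatter), so this place on the ring, para to a large group, responds to the addition of a single carbon. Among these compounds, this is the first step that isolates one change in one place, and it runs toward weaker inhibition, although compound 3 at 34.4 nM remains well inside the nanomolar range. No measurement at hand accounts for the step.

Open, from the compounds shown here alone, is whether a fluorine, a methoxy group or a carboxylic acid at the same place would follow methyl in direction and size. Also open, going by these compounds, is whether methyl on another carbon of this ring, or on the longer chain of compound 2, would give a step of similar size.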